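Swapping Fluoro for Trifluoromethyl on Compound 3

The source may hold more compounds than are shown below. What is called first, only, known or untested is meant among the compounds shown, and "the series" means these compounds.

In a functional assay on COLO 205 cells (Homo sapiens) for inhibition, read by sulforhodamine B assay (a lower number here means a stronger inhibitor of growth, a higher number a weaker inhibitor of growth), compound 3 (`Oc1cccc2[nH]c(-c3ccc(-c4ccc(-c5ccc(F)cc5)cc4)cc3)nc12`) gives 1220 nM, level with compound 2 (`Oc1cccc2[nH]c(-c3ccc(-c4ccc(-c5ccccc5)cc4)cc3)nc12`) at 1210 nM, while compound 1 (`FC(F)(F)c1ccc(-c2ccc(-c3ccc(-c4nc5ccccc5[nH]4)cc3)cc2)cc1`) is a far weaker inhibitor of growth at 33900 nM.

Compound 4 (`Oc1cccc2[nH]c(-c3ccc(-c4ccc(-c5ccc(C(F)(F)F)cc5)cc4)cc3)nc12`) has trifluoromethyl in place of fluoro on an aromatic carbon, para to a large group (trifluoromethyl in place of fluoro on an aromatic carbon).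

For the measured compounds named here, one measured step touches this same carbon, where fluoro replaced hydrogen: a 1.0-fold higher number from compound 2 to compound 3 (0.00 log units; within the scatter). That swap left the number unchanged within the scatter. Going by the values given here, no measured step tests trifluoromethyl at this carbon. Compound 1 also carries that group, but its core differs as well, so its value cannot be credited to the group alone.

With so little to go on, a step within the scatter is expected, with no firm direction. The estimated change is small (a 1.1-fold higher number from compound 3 to compound 4 (0.06 log units; within the scatter)). For compound 4 the estimated growth-inhibition value is 1400 nM, with an expected range from 550 nM to 3500 nM.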

Compound 4, concentration for 50% growth inhibition: 3410 nM
Beside the measured number, compound 4's estimate is 2.4-fold (0.39 log units) below it, and the stated range covers the measured number.
By their numbers in this assay, from the lowest: compounds 2 and 3 (each within the scatter of the next); then compound 4; then compound 1.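

Fluoro at this carbon had left the number level, but trifluoromethyl does not: in this assay it gives a weaker inhibitor of growth than fluoro (a 2.8-fold higher number from compound 3 to compound 4 (0.45 log units; beyond the scatter)) and than hydrogen (a 2.8-fold higher number from compound 2 to compound 4 (0.45 log units; beyond the scatter)). So this position does respond to what it carries, though the loss is modest and rests on a single group. Compound 4 also isolates the hydroxy group. It differs from compound 1 in that one place (a 9.9-fold lower number from compound 1 to compound 4 (1.00 log units; beyond the scatter)), showing that hydroxy on the shared core goes with stronger growth inhibition when trifluoromethyl is present. No measurement here explains why either change has the effect it does.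

On these data alone, whether a nitrile, an amine or a carboxylic acid at this carbon would match hydrogen, or even give a lower number, remains open. So does whether the step from fluoro to trifluoromethyl would be the same size on a different core.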